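Taking One Carbon off the Butyl Chain

The source may hold more compounds than are shown below. What is called first, only, known or untested is meant among the compounds shown, and "the series" means these compounds.

In a functional assay on DLD-1 cells (Homo sapiens) for cytotoxicity, with a stated time of 48 h (a lower number here means a stronger inhibitor, a higher number a weaker inhibitor), compound 1 (`Cc1ccc2c(=O)cc(/C=C/[S+](C)[O-])oc2c1`) gives 7000 nM as its half-maximal inhibitory concentration, and compound 2 (`CCCCOc1ccc2oc(/C=C/[S+](C)[O-])cc(=O)c2c1`), which carries a butyl chain, gives 4800 nM on the same read-out. These two numbers lie within the usual scatter of repeated measurements, so compound 2 stands level with compound 1 and the pair cannot be ranked. Compound 3 (`CCCOc1ccc2oc(/C=C/[S+](C)[O-])cc(=O)c2c1`) has not yet been measured. It differs from compound 2 in one place, butyl to propyl (hydrogen in place of methyl on a saturated chain carbon, three bonds along the chain from an oxygen on an aromatic ring), with hydrogen in place of methyl on a saturated chain carbon, three bonds along the chain from an oxygen on an aromatic ring. Within the data shown here, no two measured compounds differ in one place, so the data offer no direct precedent for this change. In this assay no step beyond the scatter is therefore expected, and the estimated step is a 1.1-fold higher number from compound 2 to compound 3 (0.06 log units; within the scatter) without a firm direction. Compound 3 is expected at 5500 nM (estimated range 2500 nM to 12000 nM).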

Compound 3, half-maximal inhibitory concentration: 6200 nM
For compound 3 the middle estimate is 1.1-fold (0.05 log units) below the measured one; the measured number falls inside the stated range.
By their numbers in this assay, from the lowest: compounds 2, 3 and 1 (each within the scatter of the next).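

Among these compounds, the change from butyl to propyl, with hydrogen in place of methyl on a saturated chain carbon, three bonds along the chain from an oxygen on an aromatic ring, gives in this assay a 1.3-fold higher number from compound 2 to compound 3 (0.11 log units; within the scatter) and is the first single change that can be read. At this place on the chain, the carbon that leaves makes no difference that this read-out can resolve, so compound 2 and compound 3 stand level. No other measurement is available that bears on this result.

Only this one step along the chain is shown, so it remains open whether an ethyl or a hexyl chain in place of the butyl chain would also stay level with compound 2 on the shared core. Going by these compounds, it also remains open whether an amine or a carboxylic acid at the end of the chain, in place of the plain methyl end, would give a step beyond the scatter in this assay on this same core.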